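A few compounds are considered here, and "the series" means these few. Any claim that something is new, unique, unknown or untested is made for them only; others in the source may bear on it.

In a functional assay on MCF7 cells (Homo sapiens) for cytotoxicity, read by neutral red uptake, with a stated time of 3 days (on this read-out lower numbers stand for stronger inhibition and higher numbers for weaker inhibition), the three measured compounds stand as follows:

Compound 1 `CCCCc1c(F)c(N)c2c(=O)cc(-c3ccc(N)c(F)c3)oc2c1F`: 8800 nM
Compound 2 `Nc1ccc(-c2cc(=O)c3c(N)c(F)c(O)c(F)c3o2)cc1F`: a limit of the assay, > 10000 nM
Compound 3 `CN(C)c1c(F)c(N)c2c(=O)cc(-c3ccc(N)c(F)c3)oc2c1F`: 39 nM

Compound 3 gives the lowest of the two numbers shown; its nearest neighbour is compound 1, reached by a 230-fold lower number from compound 1 to compound 3 (2.35 log units; beyond the scatter). The change from compound 2 to compound 3 is an at least 250-fold lower number from compound 2 to compound 3 (2.40 log units; beyond the scatter), where the value of compound 2 is only a limit (the limit of > 10000 nM in this assay, at which 1 of the 3 values shown sits). Both steps into compound 3 thus show that the dimethylamino group carries a large part of its potency, while butyl and hydroxy at the same carbon give far weaker compounds.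

Compound 4 `NCc1c(F)c(N)c2c(=O)cc(-c3ccc(N)c(F)c3)oc2c1F` differs from compound 3 in one place: aminomethyl in place of dimethylamino on an aromatic carbon. Among the measured compounds shown here, no measured step involves an aminomethyl group, so the two steps into compound 3 are the only guide, and they suggest that moving away from dimethylamino is expected to cost potency, though perhaps not to the full extent seen for butyl or hydroxy, since a nitrogen is retained. Compound 4 is therefore expected to give about 600 nM in this assay, with a range of 60 nM to 6000 nM. The expected step from compound 3 is a 15-fold higher number from compound 3 to compound 4 (1.19 log units; beyond the scatter).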

Compound 4, half-maximal inhibitory concentration: 26 nM
Beside the measured number, compound 4's estimate is 23-fold (1.36 log units) above it; the whole stated range lies above it.
By their numbers in this assay, from the lowest: compounds 4 and 3 (each within the scatter of the next); then compound 1. At a limit, above all of these: compound 2.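

In this assay, this carbon, ortho to two fluoro groups, does not depend on dimethylamino: with aminomethyl in its place there is a 1.5-fold lower number from compound 3 to compound 4 (0.18 log units; within the scatter), so the change from 0 to 1 hydrogen-bond donor in the group leaves compound 3 and compound 4 within the scatter of each other. Set against the carbon chain, the amino on the carbon bound to the ring stands in place of propyl, with a 340-fold lower number from compound 1 to compound 4 (2.53 log units; beyond the scatter). Against hydroxy there is an at least 380-fold lower number from compound 2 to compound 4 (2.58 log units; beyond the scatter), a step that rests on a limit for compound 2: the limit of > 10000 nM in this assay, at which 1 of the 4 values shown sits.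

The compounds shown leave open whether the nitrogen of aminomethyl is what matters, or whether a hydroxymethyl or a plain methyl group would give a similar number. They also leave open how a longer aminoalkyl chain or a carboxylic acid at this carbon would compare.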